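The compounds below may be only part of what the source reports. "The series", "measured", "known", "first", "only" and "open" are said of these compounds alone.

Measured so far:
compound 1, `COc1ccc(C2SC(C)C(=O)Nc3c2c(C)nn3-c2ccccc2C)c(OC)c1`: 10500 nM
compound 2, `CCCc1ccccc1-n1nc(C)c2c1NC(=O)[C@H](C)S[C@@H]2c1ccc(Oc2ccccc2)cc1`: 1100 nM
compound 3, `COc1cccc(-c2ccc([C@H]3S[C@@H](C)C(=O)Nc4c3c(C)nn4-c3ccccc3C)cc2)c1`: 1800 nM

In an assay on isolated protein for agonist activity at Bile acid receptor (Homo sapiens), read by AlphaScreen, with a stated time of 30 min (a higher number here means that more compound is needed for the effect, a lower number that less compound is needed), compound 3 stands second highest of the three numbers. Its nearest neighbour is compound 2, whose number lies within the scatter of it; furthest is compound 1, whose number lies beyond the scatter. Compound 4, `Cc1ccccc1-n1nc(C)c2c1NC(=O)[C@H](C)S[C@@H]2c1ccc(-c2ccco2)cc1`, has not yet been measured in this assay. It differs from compound 3 in one place: furan-2-yl in place of 3-methoxyphenyl on an aromatic carbon. Within the data shown here, no step between two measured compounds matches this change, so its size is not known from the data. A modest rise in the number is expected, the step from compound 3 to compound 4 estimated at a 1.7-fold higher number from compound 3 to compound 4 (0.22 log units; within the scatter). For compound 4 the expected value in this assay is 3000 nM, with a range from 1000 nM to 9000 nM.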

Compound 4, half-maximal effective concentration: 3600 nM
Compound 4: middle estimate off by 1.2-fold (0.08 log units), on the low side, within the range that was stated.
By their numbers in this assay, from the lowest: compounds 2, 3 and 4 (each within the scatter of the next, the first and the last beyond it); then compound 1.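

In this assay, among these compounds, furan-2-yl in place of 3-methoxyphenyl gives a 2.0-fold higher number from compound 3 to compound 4 (0.30 log units; within the scatter) and so offers the first reading of a single change. On an aromatic carbon para to a large group, a five-membered aromatic ring with 1 hetero atom and a six-membered aromatic ring of carbon only are not told apart by this pair. Nothing at hand explains this result.

As far as these compounds go, what an amine or a carboxylic acid on this aromatic carbon would do remains open, as does the effect of a morpholine ring there.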